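A Cyclopropyl Ring in Place of Ethyl

The source may hold more compounds than are shown below. What is called first, only, known or untested is meant among the compounds shown, and "the series" means these compounds.

Compound 1, `CCCC(=O)Nc1ccc(Oc2cccc(OC)c2)cc1`: 63 nM in an assay on isolated protein for binding affinity to melatonin receptor type 1A (Homo sapiens); a higher number here means a weaker inhibitor, a lower number a stronger inhibitor
Compound 2, `CCC(=O)Nc1ccc(Oc2cccc(OC)c2)cc1`: 300 nM in this assay

Compound 2 has the higher of the two numbers, set apart by a 4.8-fold higher number from compound 1 to compound 2 (0.68 log units; beyond the scatter). Compound 3, `COc1cccc(Oc2ccc(NC(=O)C3CC3)cc2)c1`, carries cyclopropyl in place of ethyl on a carbonyl carbon. Going by the values given here, no measured step exchanges a chain for a ring; the one step at hand, a 4.8-fold higher number from compound 1 to compound 2 (0.68 log units; beyond the scatter), shows that one more carbon on the acyl chain goes with a lower number, and the cyclopropyl also brings one more carbon than ethyl. A modest fall in this assay is therefore expected, a 2.5-fold lower number from compound 2 to compound 3 (0.40 log units; beyond the scatter). Compound 3 is estimated at 120 nM, with a range from 40 nM to 400 nM.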

Compound 3, inhibition constant: 99 nM
Compound 3: middle estimate off by 1.2-fold (0.08 log units), on the high side, within the range that was stated.
By their numbers in this assay, from the lowest: compounds 1 and 3 (each within the scatter of the next); then compound 2.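

Cyclopropyl in place of ethyl on a carbonyl carbon gives a 3.0-fold lower number from compound 2 to compound 3 (0.48 log units; beyond the scatter) in this assay, so here a three-membered ring, and not only a longer chain, goes with a lower number than ethyl. Cyclopropyl in place of propyl gives a 1.6-fold higher number from compound 1 to compound 3 (0.20 log units; within the scatter), so this assay does not separate these two groups. No evidence at hand accounts for this result. Still open, from the compounds shown here alone, is whether a longer chain such as butyl, or a larger ring such as cyclobutyl, would keep the number at this level or shift it.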